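A few compounds are considered here, and "the series" means these few. Any claim that something is new, unique, unknown or untested is made for them only; others in the source may bear on it.

Of the compounds shown here, three have been measured in an ADME assay on the whole organism (strain Zucker) for pharmacokinetics, with Rattus norvegicus as the target, with a stated time of 14 days, at a dose of 3 mg/kg by the oral route; a lower number here means less compound in the circulation, a higher number more compound in the circulation at the dose given. Compound 1 `Cc1ccc(Oc2ccc3nc(COc4cccc(C(=O)O)c4)n(C)c3n2)cc1` gives 1310 nM. Going by the values given here, compound 2 `Cn1c(COc2cccc(C(=O)O)c2)nc2ccc(Oc3ccc4c(c3)CCC4)nc21` gives 1440 nM, and the single change a 1.1-fold higher number from compound 1 to compound 2 (0.04 log units; within the scatter) stays within the scatter. Compound 3 `Cn1c(COc2cccc(C(=O)O)c2)nc2ccc(Oc3ccc(Cl)cn3)cc21` gives 161 nM, the lowest of the three numbers, with compound 1 and compound 2 both standing beyond the scatter above it. Compound 4 `Cc1cnc(Oc2ccc3nc(COc4cccc(C(=O)O)c4)n(C)c3c2)c(F)c1` differs from compound 3 in one place: 3-fluoro-5-methylpyridin-2-yl in place of 5-chloropyridin-2-yl on an oxygen on an aromatic ring. Among the compounds with values here, the only measured step that bears on this, a 1.1-fold higher number from compound 1 to compound 2 (0.04 log units; within the scatter), also swapped the group on that oxygen and left the number essentially unchanged, but no step between two pyridinyl groups has been measured. A small, uncertain rise is therefore expected, a 1.6-fold higher number from compound 3 to compound 4 (0.19 log units; within the scatter). Compound 4 is estimated at 250 nM, within a range from 80 nM to 800 nM.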

Compound 4, maximal plasma concentration in the Rattus norvegicus assay: 1030 nM
Beside the measured number, compound 4's estimate is 4.1-fold (0.61 log units) below it; measured number above the stated range.
By their numbers in the Rattus norvegicus assay, from the lowest: compound 3; then compounds 4, 1 and 2 (each within the scatter of the next).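

In the Rattus norvegicus assay the group on this oxygen can clearly move the number: compound 3 gives 161 nM and compound 4 gives 1030 nM (a 6.4-fold higher number from compound 3 to compound 4 (0.81 log units; beyond the scatter)), whereas the earlier swap at this place stayed within the scatter (a 1.1-fold higher number from compound 1 to compound 2 (0.04 log units; within the scatter)). In a physicochemical assay for lipophilicity, read by LC-MS, in phosphate buffer, measured as octanol-water partition, with a stated time of 30 min, at pH 7.4, tested at 200 mM (a higher number here means a more lipophilic compound, a lower number a more polar compound), compound 3 gives 1.2 and compound 4 gives 1.1 (a number 0.10 log units lower from compound 3 to compound 4 (within the scatter)), so the distribution coefficient does not follow the rise in circulating compound. Nothing measured here explains that rise.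

Chlorine left while fluorine and methyl entered in a single step, and which of these changes carries the rise stays open. As far as these compounds go, how an amine on that pyridinyl ring would read is also open.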